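Moving a Methoxy Group on an Inactive Amide

The source may hold more compounds than are shown below. What is called first, only, known or untested is meant among the compounds shown, and "the series" means these compounds.

Three compounds were tested in a functional assay on K562 cells (Homo sapiens) for antiproliferative activity, read by CellTiter-Glo and CCK-8 assay, with a stated time of 72 h; on this read-out higher numbers stand for weaker inhibition of growth and lower numbers for stronger inhibition of growth. Compound 1 (`Cc1ccc(NC(=O)c2cccc(C(F)(F)F)c2)cc1N1Cc2cnc(Nc3ccc(C)c(C(F)(F)F)c3)nc2N(C)C1=O`) gives 29 nM in this assay, and compound 2 (`Cc1ccc(NC(=O)c2cccc(C(F)(F)F)c2)cc1N1Cc2cnc(OC3CCNCC3)nc2N(C)C1=O`) gives 220 nM. Among the measured compounds shown here, the one measured step, a 7.6-fold higher number from compound 1 to compound 2 (0.88 log units; beyond the scatter), is the only change whose effect is known here, and it concerns a different part of a different scaffold. Compound 3 (`CNc1nc(Nc2ccc(C)c([N+](=O)[O-])c2)ncc1C(=O)Nc1cc(NC(=O)c2ccccc2OC)ccc1C`) is a different case: in this assay compound 3 reaches only the limit of > 10000 nM, so no number is known for it, and the limit of > 10000 nM in this assay, at which 1 of the 3 values shown sits, records that this is a limit of the assay rather than a measurement.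

Compound 4 (`CNc1nc(Nc2ccc(C)c([N+](=O)[O-])c2)ncc1C(=O)Nc1cc(NC(=O)c2ccc(OC)cc2)ccc1C`) is related to compound 3 by 4-methoxyphenyl in place of 2-methoxyphenyl on a carbonyl carbon. For the measured compounds named here, no measured step bears on this change, so nothing in the data predicts a shift in either direction beyond the scatter. Starting from a compound that is already past the limit, compound 4 is expected to give about 15000 nM, with a range from 4000 nM to 60000 nM. That estimate corresponds to an expected step that the limit leaves unreadable from compound 3 to compound 4.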

Compound 4, concentration for 50% growth inhibition: 1530 nM
For compound 4 the middle estimate is 9.8-fold (0.99 log units) above the measured one, and the stated range ends above it.
By their numbers in this assay, from the lowest: compound 1; then compound 2; then compound 4. At a limit, above all of these: compound 3.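

Moving the methoxy group on this carbonyl carbon's aromatic ring, from 2-methoxyphenyl to 4-methoxyphenyl, gives in this assay an at least 6.5-fold lower number from compound 3 to compound 4 (0.81 log units; beyond the scatter). Among the compounds shown here, this is the first sign that this amide position matters, and it shows that the placement of one group can change growth inhibition even though the two compounds have the same atoms and the same counted donors and acceptors. Compound 3 stands at a limit and not at a number, so the step gives a minimum size and no exact one: the limit of > 10000 nM in this assay, at which 1 of the 4 values shown sits.

The compounds shown leave open how an unsubstituted phenyl, a 3-methoxyphenyl or a 4-ethoxyphenyl would behave on this carbonyl carbon. They also cannot tell whether the same move would have a comparable effect on the core of compound 1.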